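Dienone series: replacing trifluoromethyl with diethoxymethyl

The compounds below may be only part of what the source reports. "The series", "measured", "known", "first", "only" and "open" are said of these compounds alone.

Measured so far:
compound 1 `CC1=C(/C=C/C(=O)/C=C/c2cccc(C(F)(F)F)c2)C(C)(C)CCC1O` 740 nM
compound 2 `CC1=C(/C=C/C(=O)/C=C/c2cc(C(F)(F)F)ccc2F)C(C)(C)CCC1O` 1700 nM

Compound 1 gives the lower of the two numbers recorded in a functional assay on LNCaP cells (Homo sapiens) for cytotoxicity, read by MTT assay, with a stated time of 72 h; a lower number here means a stronger inhibitor, a higher number a weaker inhibitor; the nearest comparison is compound 2, which sits a 2.3-fold higher number from compound 1 to compound 2 (0.36 log units; beyond the scatter) away after fluoro in place of hydrogen on an aromatic carbon. For the measured compounds named here, that is the only step measured in the set, and it concerns a different change at a different position from the one now considered.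

Compound 3 `CCOC(OCC)c1cccc(/C=C/C(=O)/C=C/C2=C(C)C(O)CCC2(C)C)c1` differs from compound 1 by diethoxymethyl in place of trifluoromethyl on an aromatic carbon. Going by the values given here, no measured step swaps the trifluoromethyl itself, so the size and direction of the effect on this assay cannot be read from the data; the single step from compound 1 to compound 2 shows only that a small change on the aryl ring can move the number by a modest amount beyond the scatter. The expectation is therefore a step of uncertain direction, most likely modest in size, a 1.6-fold higher number from compound 1 to compound 3 (0.21 log units; within the scatter), with a wide range allowed. Compound 3 is estimated at 1200 nM in this assay, with a range from 400 nM to 4000 nM.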

Compound 3, half-maximal inhibitory concentration: 1800 nM
Compound 3: the middle estimate sits 1.5-fold (0.18 log units) below what was measured, within the range that was stated.
By their numbers in this assay, from the lowest: compound 1; then compounds 2 and 3 (each within the scatter of the next).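

In this assay, for the compounds shown here, the trifluoromethyl group itself is exchanged for the first time, giving a 2.4-fold higher number from compound 1 to compound 3 (0.39 log units; beyond the scatter), so this change at this position has a direction and a size, which the earlier step at a different place on the aryl ring could not show. On this aromatic carbon, meta to a large group, diethoxymethyl brings 7 heavy atoms in place of 4 and 2 hydrogen-bond acceptors in place of 0, yet the cost in this single pair is modest and the read-out stays measurable. Nothing in hand bears on what lies behind the step.

One exchange cannot show whether the size of the group or its oxygen atoms matter more, and a dimethoxymethyl, a nitrile, an aldehyde, a carboxylic acid or an amine on the same carbon would begin to separate the two. From the compounds shown here alone, it also remains open whether the same exchange would give a similar step on the fluoro-substituted ring of compound 2, or whether the step holds only with the ring pattern of compound 1.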